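The source may report more compounds than this note shows. Statements on the series, on what has been measured and on what is new or still open speak of the compounds shown alone.

Measured compounds: compound 1 `CC(C)(C)c1ccc(C(=O)N2CCC3(CC2)C(=O)N(CC(=O)N2CCC(CCO)CC2)CN3c2ccccc2)cc1` gives 2600 nM in an assay on HEK293 cells for displacement of a labelled ligand from NPC1-like intracellular cholesterol transporter 1 (Homo sapiens); a higher number here means a weaker inhibitor, a lower number a stronger inhibitor; compound 2 `CC(C)(C)OC(=O)NC1CCCN(C(=O)CN2CN(c3ccccc3)C3(CCN(C(=O)c4ccc(C(C)(C)C)cc4)CC3)C2=O)C1` gives 4200 nM; compound 3 `CC(C)(C)c1ccc(C(=O)N2CCC3(CC2)C(=O)N(CC(=O)NCCN)CN3c2ccccc2)cc1` gives 7000 nM.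

Compound 3 sits at the high end of the three numbers: compound 1 is below it beyond the scatter, as a 2.7-fold higher number from compound 1 to compound 3 (0.43 log units; beyond the scatter) shows, while compound 2 and compound 3 lie within the scatter of each other. Compound 4 `CC1CCCN(C(=O)CN2CN(c3ccccc3)C3(CCN(C(=O)c4ccc(C(C)(C)C)cc4)CC3)C2=O)C1` is not yet measured; it differs from compound 3 by 3-methylpiperidin-1-yl in place of (2-aminoethyl)amino on a carbonyl carbon. For the measured compounds named here, the one step that bears on this is the reverse of the change from compound 1, where a piperidinyl amide stood in place of the open-chain amine; compounds 1 and 2 both carry such a piperidinyl amide and both give lower numbers than compound 3. Compound 4 is therefore expected to give a modestly lower number, a 2.3-fold lower number from compound 3 to compound 4 (0.37 log units; beyond the scatter), with an estimate of 3000 nM (range 1200 nM to 7500 nM).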

Compound 4, half-maximal inhibitory concentration: 12000 nM
Estimate against measurement, compound 4: 4.0-fold (0.60 log units) below, and the stated range ends below it.
By their numbers in this assay, from the lowest: compounds 1, 2, 3 and 4 (each within the scatter of the next, the first and the last beyond it).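

The step of a 1.7-fold higher number from compound 3 to compound 4 (0.23 log units; within the scatter) in this assay means that a piperidinyl amide in itself brings no lower number than the open chain. What the ring carries matters instead: 3-methylpiperidin-1-yl in place of 4-(2-hydroxyethyl)piperidin-1-yl gives a 4.6-fold higher number from compound 1 to compound 4 (0.66 log units; beyond the scatter) and methyl in place of (tert-butoxycarbonyl)amino on a saturated ring carbon gives a 2.9-fold higher number from compound 2 to compound 4 (0.46 log units; beyond the scatter) in this series. No available data account for these steps. Open, on these data alone, is whether a free amine, a carboxylic acid or a longer hydroxyalkyl chain on the ring would lower the number further, and how far the ring position of the group contributes.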